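The source may hold more compounds than are shown below. What is called first, only, known or untested is meant among the compounds shown, and "the series" means these compounds.

Within the data shown here, in a functional assay on SK-OV-3 cells (Homo sapiens) for cytotoxicity, read by MTT assay, with a stated time of 48 h (on this read-out lower numbers stand for stronger inhibition and higher numbers for weaker inhibition), compound 1 `O=C(/C=C/c1ccc2c(c1)B(O)OC2)c1cccs1` gives 10400 nM, the highest of the three numbers known so far. Two related compounds keep the shared core and change only the group on the carbonyl carbon: compound 2 `O=C(/C=C/c1ccc2c(c1)B(O)OC2)c1ccc(Br)cc1` gives 4500 nM, and compound 3 `Cc1ccc(C(=O)/C=C/c2ccc3c(c2)B(O)OC3)cc1` gives 3700 nM. The steps of a 2.3-fold lower number from compound 1 to compound 2 (0.36 log units; beyond the scatter) and a 2.8-fold lower number from compound 1 to compound 3 (0.45 log units; beyond the scatter) each lower the number modestly, while the step of a 1.2-fold lower number from compound 2 to compound 3 (0.09 log units; within the scatter) falls within the scatter, so the two substituted phenyl groups cannot be told apart on these data.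

Compound 4 `Nc1cccc(C(=O)/C=C/c2ccc3c(c2)B(O)OC3)c1` has not yet been measured in this assay. It differs from compound 1 in one place: 3-aminophenyl in place of thiophen-2-yl on a carbonyl carbon. Both measured steps from compound 1 bear on this change, since each of them also replaces the thiophen-2-yl on the carbonyl carbon with a substituted phenyl, and each gave a modest lowering beyond the scatter. Whether an amino group acts like the bromo or methyl groups cannot be read from these compounds, so the outcome may also stay within the scatter of compound 1. Compound 4 is therefore expected to show a similar modest lowering, a 2.3-fold lower number from compound 1 to compound 4 (0.36 log units; beyond the scatter). Compound 4 is estimated at 4500 nM, with a range from 2000 nM to 11000 nM.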

Compound 4, half-maximal inhibitory concentration: 7400 nM
For compound 4 the middle estimate is 1.6-fold (0.22 log units) below the measured one; low and high end bracket the measured number.
By their numbers in this assay, from the lowest: compounds 3, 2, 4 and 1 (each within the scatter of the next, the first and the last beyond it).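

In this assay the swap of thiophen-2-yl for a substituted phenyl on the carbonyl carbon does not always carry the number beyond the scatter: with 3-aminophenyl the result is a 1.4-fold lower number from compound 1 to compound 4 (0.15 log units; within the scatter) and so the clear steps seen with 4-bromophenyl and 4-methylphenyl do not extend to every substituted phenyl group. The new group also cannot be separated from those two, with a 2.0-fold higher number from compound 3 to compound 4 (0.30 log units; within the scatter) and a 1.6-fold higher number from compound 2 to compound 4 (0.22 log units; within the scatter) so compound 4 lies within the scatter of compounds 1, 2 and 3, while compounds 2 and 3 remain beyond the scatter of compound 1. No measurement available here explains these differences.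

The compounds shown change both the group on the phenyl ring and its numbered place, so the effect of amino itself cannot be separated from the effect of its place; 4-aminophenyl and 3-methylphenyl would each give a comparison that changes only one of these. Plain phenyl, with no added group, would show how much of any step comes from replacing thiophen-2-yl with a phenyl ring alone.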